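The source may report more compounds than this note shows. Statements on the series, on what has been measured and on what is new or still open speak of the compounds shown alone.

Working notes on the series. The pair under study is compound 1 `CS/C(=N\C(=O)c1cc(-c2ccccc2)nc2ccccc12)NC(=O)c1cc(-c2ccccc2)nc2ccccc12` and the unmeasured compound 3 `O=C(/N=C(/NC(=O)c1cc(-c2ccccc2)nc2ccccc12)[Se]Cc1ccccc1)c1cc(-c2ccccc2)nc2ccccc12`, both read in a functional assay on K562 cells (Homo sapiens) for cytotoxicity, read by MTT assay, with a stated time of 72 h; a higher number here means that more compound is tolerated, a lower number that less compound is tolerated. For compound 1 the assay reports only the limit > 100000 nM, so its true value is not known as a number (the limit of > 100000 nM in this assay, at which 1 of the 2 values shown sits). The other measured member, compound 2 `O=C(/N=C(/NC(=O)c1ccco1)[Se]Cc1ccccc1)c1ccco1`, carries the same selenium-bearing group on a furan-based frame and in this assay compound 2 gives 80600 nM. The change from compound 1 to compound 3 is a group of 8 heavy atoms (7 carbon, 1 selenium; one six-membered aromatic ring of carbon only) in place of a group of 2 heavy atoms (1 carbon, 1 sulfur; no ring), on a carbon with a double bond to nitrogen. Since compound 1 sits at the limit, the step to compound 3 is expected to read as a move to a lower number, with size an at least 1.6-fold lower number from compound 1 to compound 3 (0.22 log units; that floor lies within the scatter), though whether it exceeds the scatter is uncertain. Among the measured compounds shown here, with compound 2 giving 80600 nM as the only guide, compound 3 is estimated at 60000 nM, within 20000 nM to 150000 nM.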

Compound 3, concentration lethal to 50% of the cells: 88900 nM
Estimate against measurement, compound 3: 1.5-fold (0.17 log units) below; the range from low to high includes it.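

In this assay compound 3 gives 88900 nM as a true number on this shared core, with the selenium-bearing group and its six-membered aromatic ring in place of methylsulfanyl on the carbon with a double bond to nitrogen. Compound 1 gives > 100000 nM as a limit of the assay and not a number. The change reads only as an at least 1.1-fold lower number from compound 1 to compound 3 (0.05 log units; that floor lies within the scatter) and so does not establish a difference beyond the scatter, and its true size cannot be read: the limit of > 100000 nM in this assay, at which 1 of the 3 values shown sits.

The compounds shown do not separate the selenium from the aromatic ring, which a sulfur atom carrying the same ring or a selenium atom carrying a methyl group would do. As far as these compounds go, how an amine or a carboxylic acid on that ring, or a longer chain on the selenium, would read in this assay also stays open.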